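The source may hold more compounds than are shown below. What is called first, only, known or untested is meant among the compounds shown, and "the series" means these compounds.

Working notes on the series.

In an ADME assay for pharmacokinetics, read by LC-MS, in phosphate buffer, with a stated time of 72 h, at pH 7.4, tested at 250 uM (on this read-out higher numbers stand for a longer-lived compound and lower numbers for a shorter-lived compound), compound 3 `O=C(CBr)c1cc(C(F)(F)F)cc(C(F)(F)F)c1` returns < 0.017 h, which is a limit of the assay rather than a number (the limit of < 0.017 h in this assay, at which 1 of the 3 values shown sits). It sits at the bottom of the values shown. Compound 1 `C=CC(=O)Nc1cc(C(F)(F)F)cc(C(F)(F)F)c1` gives 5.5 h in this assay. Compound 2 `N#Cc1cc(C(F)(F)F)cc(C(F)(F)F)c1` gives > 50 h in this assay, again a limit of the assay (the limit of > 50 h in this assay, at which 1 of the 3 values shown sits).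

Compound 4 `FC(F)(F)c1cc(S)cc(C(F)(F)F)c1` differs from compound 3 in one place: sulfanyl in place of (bromomethyl)carbonyl on an aromatic carbon. The (bromomethyl)carbonyl group that leaves is the one whose arrival cost an at least 320-fold lower number from compound 1 to compound 3 (2.50 log units; beyond the scatter) and an at least 2900-fold lower number from compound 2 to compound 3 (3.46 log units; beyond the scatter). Both steps are large and point the same way, so its removal is expected to raise the half-life by a large margin. How far a sulfanyl group stands from the (vinylcarbonyl)amino group of compound 1 or the cyano group of compound 2 is not shown by any measured pair, so the size of the rise is uncertain.

Compound 4 is estimated at 15 h in this assay, within 2 h to 50 h, which corresponds to an expected at least 880-fold higher number from compound 3 to compound 4 (2.94 log units; beyond the scatter).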

Compound 4, half-life: > 50 h
Compound 4: a limit, no number; the forecaster's own chance of this, stated with the estimate: 25%; at least 3.3-fold (0.52 log units) between middle value and limit.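

In this assay, the sulfanyl group at this aromatic carbon gives an at least 2900-fold higher number from compound 3 to compound 4 (3.46 log units; beyond the scatter) and an at least 9.0-fold higher number from compound 1 to compound 4 (0.95 log units; beyond the scatter). The cyano group of compound 2 is therefore no longer the only group shown at this place to reach the upper limit of the read-out: the limit of > 50 h in this assay, at which 2 of the 4 values shown sit. The step between compound 2 and compound 4 cannot be read, as both values are limits, so the two groups cannot be placed in any order.

Going by these compounds, how long either compound lasts past the limit stays open. Also open, on these data alone, is whether an amine or a carboxylic acid at the same aromatic carbon would reach that limit too, or fall closer to compound 1 on the shared core.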